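The source may hold more compounds than are shown below. What is called first, only, known or untested is meant among the compounds shown, and "the series" means these compounds.

Working notes on the series. Compound 3 `COc1cc(/C=C/C(=O)/C=C/c2ccccc2)ccc1OCc1cn(CCOc2cc(=O)oc3ccccc23)nn1` and compound 1 `COc1cc(/C=C/C(=O)/C=C/c2cc(OC)c(OC)c(OC)c2)ccc1OCc1cn(CCOc2cc(=O)oc3ccccc23)nn1` share a core; they differ by 3,4,5-trimethoxyphenyl in place of phenyl on a double-bonded chain carbon bound to a double-bonded chain carbon. In a functional assay on PC-3 cells (Homo sapiens) for inhibition, read by sulforhodamine B assay, with a stated time of 48 h, tested at 50 uM (a higher number here means more inhibition of growth at the concentration tested, a lower number less inhibition of growth), compound 3 gives 10% and compound 1 gives 22%, so the step of a number 12 percentage points higher from compound 3 to compound 1 (beyond the scatter). Compound 2 `COc1cc(/C=C/C(=O)/C=C/c2ccccc2)ccc1OCc1cn(CCCCCOc2cc(=O)oc3ccccc23)nn1` carries the same phenyl as compound 3 but a different core; the difference between the two cores is not broken down here. In this assay compound 2 gives "not active" (no number reported), with no number attached. Compound 4 `COc1cc(/C=C/C(=O)/C=C/c2cc(OC)c(OC)c(OC)c2)ccc1OCc1cn(CCCCCOc2cc(=O)oc3ccccc23)nn1` has the core of compound 2 and differs from it by 3,4,5-trimethoxyphenyl in place of phenyl on a double-bonded chain carbon bound to a double-bonded chain carbon, which is the same change as that from compound 3 to compound 1. A step of similar, modest size is expected from compound 2 to compound 4, resting on a number 12 percentage points higher from compound 3 to compound 1 (beyond the scatter), though the starting point of compound 2 is only a report of no activity. In this assay compound 4 is estimated at 12%, expected to fall between 0% and 25%.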

Compound 4, percent growth inhibition at one concentration: "not active" (no number reported)
Compound 4 has no reported number here; there is nothing to compare the estimate with.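

Among the compounds shown here, compound 2 and compound 4 both lack a number, so no step between them can be read. Going by these compounds, whether 3,4,5-trimethoxyphenyl in place of phenyl changes anything on this core stays open. No evidence bears on this result.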